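Urea side chain change from compound 2 to compound 3

This account rests on a few compounds, and the source may have more. Where it says the series, first, only, none or still open, it means among the compounds named here.

In a functional assay on A549 cells (Homo sapiens) for cytotoxicity, read by MTT assay, with a stated time of 72 h (a higher number here means a weaker inhibitor, a lower number a stronger inhibitor), compound 1 `COc1ncc(-c2ccc3nc(NC(=O)NCC(=O)N4CCCCC4)nn3c2)cc1NS(=O)(=O)c1ccc(F)cc1` gives 2060 nM and compound 2 `COc1ncc(-c2ccc3nc(NC(=O)N(C)C)nn3c2)cc1NS(=O)(=O)c1ccc(F)cc1` gives 1190 nM. These two values lie within the scatter of each other, so compound 2 cannot be told apart from compound 1 on these numbers. Compound 3 `COc1ncc(-c2ccc3nc(NC(=O)NCCN4CCCC4)nn3c2)cc1NS(=O)(=O)c1ccc(F)cc1` keeps the shared core and carries one change: (2-(pyrrolidin-1-yl)ethyl)amino in place of dimethylamino on a carbonyl carbon. It has (2-(pyrrolidin-1-yl)ethyl)amino in place of dimethylamino on a carbonyl carbon. Going by the values given here, one measured step bears on this, also an exchange of groups on that carbonyl carbon: a 1.7-fold lower number from compound 1 to compound 2 (0.24 log units; within the scatter). Among the compounds with values here, with only that step as a guide, no step beyond the scatter is expected in this assay, and no direction can be assigned. For compound 3 the estimate is 1500 nM, with an expected range of 600 nM to 3800 nM. The expected step is a 1.3-fold higher number from compound 2 to compound 3 (0.10 log units; within the scatter).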

Compound 3, half-maximal inhibitory concentration: 960 nM
Estimate against measurement, compound 3: 1.6-fold (0.19 log units) above; the measured number falls inside the stated range.
By their numbers in this assay, from the lowest: compounds 3, 2 and 1 (each within the scatter of the next, the first and the last beyond it).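

In this assay, the carbonyl carbon carries (2-(pyrrolidin-1-yl)ethyl)amino, with 8 heavy atoms and a ring, in place of dimethylamino, with 3 heavy atoms and no ring, and the result is a 1.2-fold lower number from compound 2 to compound 3 (0.09 log units; within the scatter), so this much larger group gives a number that cannot be told apart from that of compound 2. Going by these compounds alone, the first step beyond the scatter is a 2.1-fold lower number from compound 1 to compound 3 (0.33 log units; beyond the scatter), with (pyrrolidin-1-yl)methyl in place of (piperidin-1-yl)carbonyl on a saturated chain carbon bound to an amide-type nitrogen, and it is modest. No measurement at hand accounts for either step.

Open, as far as these compounds go, is how a (2-(morpholin-4-yl)ethyl)amino group, or a longer chain ending in a carboxylic acid, would read on this carbonyl carbon. Also open, from the compounds shown here alone, is whether any group here can move the number beyond the scatter from compound 2.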